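The compounds below may be only part of what the source reports. "The series", "measured", "known", "first", "only" and "open" are said of these compounds alone.

Working notes on a urea series with a shared core. Compound 1 `Cc1cc(NC(=O)Nc2ccc(C)c(Cl)c2)c2ccccc2n1`, compound 2 `Cc1ccc(NC(=O)Nc2cc(C)nc3ccccc23)cc1` and compound 3 `Cc1cc(NC(=O)Nc2ccccc2F)c2ccccc2n1` have been run in an ADME assay on Raji cells (Homo sapiens) for cytotoxicity, with a stated time of 72 h; on this read-out higher numbers stand for an effect only at larger amounts of compound and lower numbers for an effect already at smaller amounts. For compound 1 the read-out is only a limit of the assay, > 25000 nM. Compound 2 likewise returns a limit, > 25000 nM. Compound 3 also gives a limit, > 25000 nM, and so it stands at the same limit as the other two values shown. The step that the two limits leave unreadable from compound 1 to compound 2, hydrogen in place of chloro on an aromatic carbon, cannot be sized, and the step that the two limits leave unreadable from compound 2 to compound 3, 2-fluorophenyl in place of 4-methylphenyl on an amide-type nitrogen, cannot be sized either, because of the limit of > 25000 nM in this assay, at which 3 of the 3 values shown sit.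

Compound 4 `Cc1cc(NC(=O)Nc2cccc(Cl)c2)c2ccccc2n1` is not yet measured in this assay. The change is 3-chlorophenyl in place of 2-fluorophenyl on an amide-type nitrogen. Both measured steps bear on it, as each alters the aryl on the amide-type nitrogen or a substituent on it, but neither gives a readable size. No step beyond the scatter is expected in this assay. The step that the limit leaves unreadable from compound 3 to compound 4 is what is expected. Compound 4 is therefore estimated at 40000 nM, with a range from 12000 nM to 120000 nM, most likely again reported as a limit.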

Compound 4, half-maximal effective concentration: 18000 nM
The estimate for compound 4 lay 2.2-fold (0.35 log units) above the measured number; low and high end bracket the measured number.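

In this assay, within the data shown here, compound 4 gives 18000 nM, the only value shown that is a number and not a limit, so this position on the amide-type nitrogen can carry a group that gives a readable value. The change to 3-chlorophenyl reads as an at least 1.3-fold lower number from compound 3 to compound 4 (0.14 log units; that floor lies within the scatter), and against the other two compounds as an at least 1.3-fold lower number from compound 2 to compound 4 (0.14 log units; that floor lies within the scatter) and an at least 1.3-fold lower number from compound 1 to compound 4 (0.14 log units; that floor lies within the scatter). All three are floors only, and their true sizes cannot be read because the partner in each step sits at a limit: the limit of > 25000 nM in this assay, at which 3 of the 4 values shown sit.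

The compounds shown leave open how far the read-out moves at this position, as no second readable value stands beside that of compound 4. Also open, from the compounds shown here alone, is what an amine or a carboxylic acid on the phenyl ring in place of chloro, or a longer chain in place of the aryl, would give.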